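A few compounds are considered here, and "the series" means these few. Any claim that something is new, unique, unknown or untested is made for them only; others in the source may bear on it.

Within the data shown here, in a functional assay on HL-60 cells (Homo sapiens) for cytotoxicity, read by luminescence and CellTiter-Glo, with a stated time of 3 days (on this read-out lower numbers stand for stronger inhibition and higher numbers for weaker inhibition), compound 3 `N#Cc1ccc(NC(=O)c2cc(-c3ccccc3)ccc2O)cc1` gives 1350 nM, the lowest of the two actual numbers so far. The other number belongs to compound 2 `N#Cc1ccc(NC(=O)c2cc(-c3ccncc3)ccc2O)cc1`, at 5410 nM. Compound 1 `COc1ccc(O)c(C(=O)Nc2ccc(C#N)cc2)c1` shows > 10000 nM, which is a limit of the assay. Compound 4 `N#Cc1ccc(NC(=O)c2cc(F)ccc2O)cc1` has fluoro in place of phenyl on an aromatic carbon, para to a hydroxy group: fluoro in place of phenyl on an aromatic carbon. The closest guide is phenyl replacing methoxy, which gave an at least 7.4-fold lower number from compound 1 to compound 3 (0.86 log units; beyond the scatter). Phenyl replacing pyridin-4-yl gave a 4.0-fold lower number from compound 2 to compound 3 (0.60 log units; beyond the scatter), while pyridin-4-yl replacing methoxy gave an at least 1.8-fold lower number from compound 1 to compound 2 (0.26 log units; that floor lies within the scatter). Losing the phenyl should therefore reverse some of that gain, so this assay is expected to show a 5.9-fold higher number from compound 3 to compound 4 (0.77 log units; beyond the scatter). The estimate for compound 4 is 8000 nM, with an expected range of 2500 nM to 20000 nM.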

Compound 4, half-maximal inhibitory concentration: 1420 nM
Beside the measured number, compound 4's estimate is 5.6-fold (0.75 log units) above it; the measured number lies below the stated range.
By their numbers in this assay, from the lowest: compounds 3 and 4 (each within the scatter of the next); then compound 2. At a limit, above all of these: compound 1.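

In this assay, fluoro in place of phenyl gives a 1.1-fold higher number from compound 3 to compound 4 (0.02 log units; within the scatter), so at this position, para to a hydroxy group, a six-membered aromatic ring is not needed to reach this level. Fluoro in place of pyridin-4-yl gives a 3.8-fold lower number from compound 2 to compound 4 (0.58 log units; beyond the scatter), which shows that pyridin-4-yl, not the loss of phenyl, goes with the weaker number. Fluoro in place of methoxy gives an at least 7.0-fold lower number from compound 1 to compound 4 (0.84 log units; beyond the scatter), only a floor, as compound 1 stands at a limit: the limit of > 10000 nM in this assay, at which 1 of the 4 values shown sits.

Still open, from the compounds shown here alone, is how a plain hydrogen, a chloro group, an amine or a carboxylic acid would read at this position.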